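The source may hold more compounds than are shown below. What is called first, only, known or untested is meant among the compounds shown, and "the series" means these compounds.

Compound 1, `CC(=O)OC/C(=C\c1ccc(Cl)cc1Cl)C(=O)c1ccccc1`, and compound 2, `CC(=O)OC/C(=C\c1ccc(Cl)cc1Cl)C(=O)c1ccc(Cl)cc1`, share one core and differ only by the change (chloro in place of hydrogen on an aromatic carbon). In a functional assay on HeLa cells (Homo sapiens) for inhibition, read by sulforhodamine B assay, with a stated time of 48 h (on this read-out higher numbers stand for weaker inhibition of growth and lower numbers for stronger inhibition of growth), compound 1 gives 16000 nM, while compound 2 gives 4600 nM, so the step reads a 3.5-fold lower number from compound 1 to compound 2 (0.54 log units; beyond the scatter). Compound 3, `C=C(C/C(=C\c1ccccc1)C(=O)c1ccccc1)C(=O)c1ccccc1`, is built on a different core; how its core differs from that of compound 1 is not broken down here. In this assay compound 3 gives 19000 nM, which sits close to the number for compound 1 and is a higher number than that of compound 2. Compound 4, `C=C(C/C(=C\c1ccc(Cl)cc1)C(=O)c1ccccc1)C(=O)c1ccccc1`, has not yet been measured. It differs from compound 3 by chloro in place of hydrogen on an aromatic carbon, the same change that turns compound 1 into compound 2, at the same place. Among the measured compounds shown here, whether the change carries over to the new core can only be judged from the single pair measured so far. Because of a 3.5-fold lower number from compound 1 to compound 2 (0.54 log units; beyond the scatter), a drop of similar size is expected in this assay, namely a 2.9-fold lower number from compound 3 to compound 4 (0.47 log units; beyond the scatter). Compound 4 is therefore estimated at 6500 nM, within a range from 2500 nM to 16000 nM.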

Compound 4, concentration for 50% growth inhibition: 22000 nM
Beside the measured number, compound 4's estimate is 3.4-fold (0.53 log units) below it; the whole stated range lies below it.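

In this assay the change from phenyl to 4-chlorophenyl gives a 1.2-fold higher number from compound 3 to compound 4 (0.06 log units; within the scatter) and so leaves the number on this core essentially where it was. The same change therefore did not carry over from one core to the other, and the two steps differ by more than the scatter allows: the same change on two cores in this assay, a 3.5-fold lower number (0.54 log units; beyond the scatter) from compound 1 to compound 2 and a 1.2-fold higher number (0.06 log units; within the scatter) from compound 3 to compound 4, 4.0-fold (0.61 log units) apart, beyond the scatter of two such steps. Among the compounds shown here, this shows that the stronger growth inhibition seen on the core of compound 1 cannot be assumed on the core of compound 3, but with only one pair on each core it does not show why the cores behave differently or what the change would do on a further core.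

The compounds shown leave open whether the core of compound 3 responds to any other group in place of this hydrogen, such as fluoro, bromo, methoxy, an amine or a carboxylic acid. They also leave open whether any of these groups would give matching steps on the two cores.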